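The compounds below may be only part of what the source reports. "The series", "measured", "known", "first", "only" and "open" are said of these compounds alone.

Compound 1 `CCn1c(=O)c2nc(-c3ccc(S(=O)(=O)O)cc3)[nH]c2n(CC)c1=O` is one of three measured compounds sharing a single core. In an assay for binding affinity to adenosine receptor A1 (Rattus norvegicus), read by radioligand binding (on this read-out lower numbers stand for stronger inhibition and higher numbers for weaker inhibition), compound 1 gives 5540 nM, the second highest of the three numbers. Compound 2 `CCn1c(=O)c2nc(-c3cccc(S(=O)(=O)O)c3)[nH]c2n(CC)c1=O` gives 30700 nM in this assay, and compound 3 `CCn1c(=O)c2nc(-c3ccc(S(=O)(=O)N4CCOCC4)cc3)[nH]c2n(CC)c1=O` gives 310 nM. For the measured compounds named here, compound 2 has no single-point step to compound 1 recorded here, so only its value stands beside that of compound 1. Compound 3 differs from compound 1 in one place, with morpholin-4-yl in place of hydroxy on a sulfonyl sulfur, and this assay shows an 18-fold lower number from compound 1 to compound 3 (1.25 log units; beyond the scatter).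

Compound 4 `CCn1c(=O)c2nc(-c3ccc(S(=O)(=O)NCCN(C)C)cc3)[nH]c2n(CC)c1=O` is not yet measured. It differs from compound 1 by (2-(dimethylamino)ethyl)amino in place of hydroxy on a sulfonyl sulfur. The change sits on the same sulfonyl sulfur as the step to compound 3, and again a hydroxy leaves while a nitrogen-linked group enters. Going by the values given here, that one step is the only measured guide, and it was large and downward. For compound 4 a lower number than for compound 1 is therefore expected, though with a different entering group the size is uncertain, and the estimated step is a 9.2-fold lower number from compound 1 to compound 4 (0.97 log units; beyond the scatter). Compound 4 is expected to give about 600 nM in this assay, within a range from 120 nM to 3000 nM.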

Compound 4, half-maximal inhibitory concentration in the adenosine receptor A1 assay: 116 nM
Compound 4: middle estimate off by 5.2-fold (0.71 log units), on the high side, outside the stated range (below it).
By their numbers in the adenosine receptor A1 assay, from the lowest: compound 4; then compound 3; then compound 1; then compound 2.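

Replacing hydroxy on the sulfonyl sulfur with a second nitrogen-linked group also lowers the number in the adenosine receptor A1 assay, a 48-fold lower number from compound 1 to compound 4 (1.68 log units; beyond the scatter), so the drop is not tied to morpholin-4-yl alone, and the two entering groups are not equivalent either, a 2.7-fold lower number from compound 3 to compound 4 (0.43 log units; beyond the scatter). In a physicochemical assay for solubility (on this read-out higher numbers stand for higher solubility and lower numbers for lower solubility), compound 1 gives > 8000 ug/mL, which is a limit of the assay and not a number, and the step to compound 4 cannot be read because of it: the limit of > 8000 ug/mL in the physicochemical assay, at which 1 of the 2 values shown sits. In the physicochemical assay compound 4 gives 11500 ug/mL, so a measured value in this second read-out stands alongside its low number in the adenosine receptor A1 assay.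

A plain ethylamino group, or a longer chain ending in the same dimethylamino group, on the sulfonyl sulfur would show whether the lower number depends on that dimethylamino end or on the length of the chain. On these data alone, whether the same replacement would act alike on compound 2 remains open, as does the value of compound 3 in the physicochemical assay.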